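Adding a bromo group to compound 2

A few compounds are considered here, and "the series" means these few. Any claim that something is new, unique, unknown or untested is made for them only; others in the source may bear on it.

Compound 1 `O=C(Nc1cccc(F)c1)c1cc(Cl)ccc1O`: 15000 nM
Compound 2 `O=C(Nc1cc(F)cc(F)c1)c1cc(Cl)ccc1O`: 6100 nM

Both values come from an ADME assay on cells (Macrophage, Mus musculus) for cytotoxicity, read by resazurin assay, with a stated time of 3 days; a higher number here means a weaker inhibitor, a lower number a stronger inhibitor. Of the two compounds, compound 2 stands lower, at 6100 nM. Compound 3 `O=C(Nc1cc(F)c(Br)c(F)c1)c1cc(Cl)ccc1O` has not yet been measured. It differs from compound 2 by a single change, bromo in place of hydrogen on an aromatic carbon: a bromo in place of hydrogen on an aromatic carbon, ortho to two fluoro groups and para to a large group.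

Among the compounds with values here, only one measured step bears on this change: a 2.5-fold lower number from compound 1 to compound 2 (0.39 log units; beyond the scatter). That step is modest but beyond the scatter, and it also replaces hydrogen on an aromatic carbon, though with a fluoro rather than a bromo. Within the data shown here, no measured compound carries a bromo, so this evidence is thin. A similarly modest move toward a lower number in this assay is expected, although a result within the scatter of compound 2 would not be surprising. The expected change is a 2.0-fold lower number from compound 2 to compound 3 (0.31 log units; beyond the scatter). For compound 3 the estimated value is 3000 nM, with an expected range of 1200 nM to 6500 nM.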

Compound 3, half-maximal inhibitory concentration: 4300 nM
Beside the measured number, compound 3's estimate is 1.4-fold (0.16 log units) below it; measured number inside the range.
By their numbers in this assay, from the lowest: compounds 3 and 2 (each within the scatter of the next); then compound 1.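

In this assay, a bromo on the aromatic carbon ortho to two fluoro groups and para to a large group gives a 1.4-fold lower number from compound 2 to compound 3 (0.15 log units; within the scatter), so this change at this position leaves compound 2 and compound 3 indistinguishable in this read-out, even though the entering group adds a heavy atom and the position is flanked by the two fluoro groups. The earlier replacement of hydrogen on an aromatic carbon, a 2.5-fold lower number from compound 1 to compound 2 (0.39 log units; beyond the scatter), lay beyond the scatter, and the bromo change shows that such a result does not carry over to every replacement of hydrogen on this aromatic ring. Nothing measured alongside these numbers offers an explanation for this result.

With one bromo compound at one position, the compounds shown leave open whether a bromo placed elsewhere on this ring would give a step beyond the scatter. They also leave open whether a different group at this same carbon, such as a methoxy, an amine or a carboxylic acid, would separate from compound 2 where the bromo does not.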